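The source may report more compounds than this note shows. Statements on the series, on what has been measured and on what is new or still open speak of the compounds shown alone.

Values in an ADME assay on HaCaT cells (Homo sapiens) for antiproliferative activity, with a stated time of 48 h; on this read-out higher numbers stand for weaker inhibition and lower numbers for stronger inhibition:

- Compound 1 `CC(=O)c1ccc(-c2ccc(N3CCCC3)nn2)cc1`: > 25000 nM (a limit of the assay)
- Compound 2 `CCN(CC)c1ccc(-c2ccc(C(C)=O)cc2)nn1`: 20000 nM
- Compound 3 `CCN(CC)c1ccc(-c2ccc(C(=O)OC)cc2)nn1`: 80 nM

Of the two values that are actual numbers, the lower belongs to compound 3, at 80 nM, so it shows the stronger inhibition of the pair. Compound 4 `CCOC(=O)c1ccc(-c2ccc(N(CC)CC)nn2)cc1` has not yet been measured. It differs from compound 3 by methyl in place of hydrogen on a saturated chain carbon bound to an oxygen next to a carbonyl group, which turns methoxycarbonyl into ethoxycarbonyl.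

The most relevant measured change is a 250-fold lower number from compound 2 to compound 3 (2.40 log units; beyond the scatter). This large step came from placing methoxy instead of methyl on the same carbonyl carbon. Compound 4 keeps that oxygen and only lengthens the chain on it, so a much smaller change seems likely, although the size of a 250-fold lower number from compound 2 to compound 3 (2.40 log units; beyond the scatter) argues for a wide range. The other measured change, an at least 1.2-fold lower number from compound 1 to compound 2 (0.09 log units; that floor lies within the scatter), concerns the diethylamino group, which compound 4 leaves untouched, and so offers little guidance.

A modest rise is expected, estimated as a 2.5-fold higher number from compound 3 to compound 4 (0.40 log units; beyond the scatter). For compound 4 the expected value is 200 nM, with an estimated range of 40 nM to 2000 nM.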

Compound 4, half-maximal inhibitory concentration: 500 nM
Compound 4: middle estimate off by 2.5-fold (0.40 log units), on the low side, within the range that was stated.
By their numbers in this assay, from the lowest: compound 3; then compound 4; then compound 2. At a limit, above all of these: compound 1.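

In this assay, the step from methoxycarbonyl to ethoxycarbonyl gives a 6.3-fold higher number from compound 3 to compound 4 (0.80 log units; beyond the scatter) and so shows that this part of the molecule is sensitive to a very small change: a single methyl on a saturated chain carbon bound to an oxygen next to a carbonyl group. The earlier compounds shown here showed a large gain only for methoxy in place of methyl on a carbonyl carbon, whereas ethoxy in that place gives a 40-fold lower number from compound 2 to compound 4 (1.60 log units; beyond the scatter) and so shows that the gain does not belong to methoxy alone. Ethoxy keeps much of that gain but gives part of it back, so the oxygen on the carbonyl carbon and the chain attached to that oxygen both count in this assay.

The compounds shown leave open whether a longer chain such as propoxy would raise the number further, and whether an amide or a carboxylic acid on the same carbonyl carbon would keep a low number. Nothing shown here gives a reason why one added methyl moves the number this far.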